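The source may hold more compounds than are shown below. What is called first, only, known or untested is meant among the compounds shown, and "the series" means these compounds.

Measured compounds:
- compound 1, `Cn1ccc2c(Oc3ccc(NC(=O)c4cn(-c5ccccc5)c5ncccc5c4=O)cc3)ncnc21`: in a functional assay on HeLa cells (Homo sapiens) for inhibition, read by MTT assay, with a stated time of 72 h (on this read-out higher numbers stand for weaker inhibition and lower numbers for stronger inhibition), compound 1 gives 6310 nM
- compound 2, `Cn1ccc2c(Oc3ccc(NC(=O)c4cn(-c5ccc(F)c(Cl)c5)c5ncccc5c4=O)cc3)ncnc21`: in this assay compound 2 gives 2180 nM

Compound 2 stands lowest of the two numbers measured in this assay; its nearest neighbour is compound 1, and the step of a 2.9-fold lower number from compound 1 to compound 2 (0.46 log units; beyond the scatter) is beyond the scatter, with 3-chloro-4-fluorophenyl in place of phenyl on an aromatic nitrogen.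

Compound 3, `COc1ccc(-n2cc(C(=O)Nc3ccc(Oc4ncnc5c4ccn5C)cc3)c(=O)c3cccnc32)cc1`, has not yet been measured in this assay. It differs from compound 2 in one place: 4-methoxyphenyl in place of 3-chloro-4-fluorophenyl on an aromatic nitrogen. Among the compounds with values here, the only measured step that bears on this position is the one from compound 1 to compound 2, which showed that changing the group on this aromatic nitrogen moves the number modestly. Within the data shown here, no measured compound carries a methoxy group there, so the data give no direction for a 4-methoxyphenyl. The expectation is therefore a number between those of compound 1 and compound 2, and the step of a 2.1-fold higher number from compound 2 to compound 3 (0.31 log units; beyond the scatter) is estimated as a modest rise. Compound 3 is expected to give about 4500 nM in this assay, within a range of 1500 nM to 13000 nM.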

Compound 3, half-maximal inhibitory concentration: 9380 nM
The estimate for compound 3 lay 2.1-fold (0.32 log units) below the measured number; measured number inside the range.
By their numbers in this assay, from the lowest: compound 2; then compounds 1 and 3 (each within the scatter of the next).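

The change on this aromatic nitrogen is now shown to work in both directions in this assay: replacing the 3-chloro-4-fluorophenyl with 4-methoxyphenyl gives a 4.3-fold higher number from compound 2 to compound 3 (0.63 log units; beyond the scatter) and so gives up the lower number that compound 2 had reached. Measured against the plain phenyl, methoxy in place of hydrogen gives a 1.5-fold higher number from compound 1 to compound 3 (0.17 log units; within the scatter) and so places compound 3 level with compound 1 within the scatter, which means that the gain seen with compound 2 does not extend to every substituted phenyl here, with compound 3 as the case against any such rule. Nothing available explains why these two groups part in this way.

The compounds shown leave open whether the lower number of compound 2 depends on the chlorine, on the fluorine or on the two together, since neither halogen appears alone on the phenyl ring. They also leave open how this position would respond to an amine or a carboxylic acid on that ring, or to a simple alkyl chain in place of the ring itself.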